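Three Measured Sulfonylureas and an Unmeasured Fluorophenyl Analogue

This account rests on a few compounds, and the source may have more. Where it says the series, first, only, none or still open, it means among the compounds named here.

Compound 1 `Cc1ccc(S(=O)(=O)NC(=O)Nc2ccccc2C(=O)/C=C/c2ccccc2)cc1`, compound 2 `Cc1ccc(S(=O)(=O)NC(=O)Nc2ccccc2C(=O)/C=C/c2ccc(N(C)C)cc2)cc1` and compound 3 `Cc1ccc(S(=O)(=O)NC(=O)Nc2ccccc2C(=O)/C=C/c2ccccc2[N+](=O)[O-])cc1` share one core and were tested in an ADME assay on the whole organism for cytotoxicity, with Artemia salina as the target, with a stated time of 24 h; a higher number here means that more compound is needed for the effect, a lower number that less compound is needed. Compound 1 gives 25 ug/mL, compound 2 gives 38.1 ug/mL and compound 3 gives 40.1 ug/mL. Compound 2 holds the second highest of the three numbers; its nearest neighbour is compound 3 and its furthest is compound 1, and both gaps stay within the scatter, so the three compounds cannot be told apart. The changes between them read a 1.5-fold higher number from compound 1 to compound 2 (0.18 log units; within the scatter), a 1.6-fold higher number from compound 1 to compound 3 (0.21 log units; within the scatter) and a 1.1-fold higher number from compound 2 to compound 3 (0.02 log units; within the scatter).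

Compound 4 `Cc1ccc(S(=O)(=O)NC(=O)Nc2ccccc2C(=O)/C=C/c2cccc(F)c2)cc1` has not yet been measured. It differs from compound 2 in this way: 3-fluorophenyl in place of 4-(dimethylamino)phenyl on a double-bonded chain carbon bound to a double-bonded chain carbon. For the measured compounds named here, two measured steps touch the same place. The step of a 1.5-fold higher number from compound 1 to compound 2 (0.18 log units; within the scatter) and the step of a 1.1-fold higher number from compound 2 to compound 3 (0.02 log units; within the scatter) each swapped the group on that chain carbon and each stayed within the scatter. No step beyond the scatter is therefore expected in this assay for this change. Compound 4 is expected to give about 30 ug/mL, in a range from 14 ug/mL to 65 ug/mL, which means an estimated step of a 1.3-fold lower number from compound 2 to compound 4 (0.10 log units; within the scatter).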

Compound 4, concentration for half-maximal effect: 4.13 ug/mL
Estimate against measurement, compound 4: 7.3-fold (0.86 log units) above, outside the stated range (below it).
By their numbers in this assay, from the lowest: compound 4; then compounds 1, 2 and 3 (each within the scatter of the next).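

In this assay, for the compounds shown here, the group on the double-bonded chain carbon bound to a double-bonded chain carbon now proves able to move the number: 3-fluorophenyl gives a 9.2-fold lower number from compound 2 to compound 4 (0.96 log units; beyond the scatter) and a 9.7-fold lower number from compound 3 to compound 4 (0.99 log units; beyond the scatter), whereas the swaps among the earlier compounds all stayed within the scatter. The smallest change shows the same thing, since adding fluoro alone gives a 6.1-fold lower number from compound 1 to compound 4 (0.78 log units; beyond the scatter), a step beyond the scatter that neither dimethylamino nor nitro in place of hydrogen produced. Nothing measured here accounts for this difference.

The compounds shown leave open whether the drop is particular to fluoro or would also appear with chloro, bromo or methoxy. They also leave open whether fluoro on another aromatic carbon of that ring would give a step of similar size.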